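A chloro on the propanoyl chain of compound 1

This account rests on a few compounds, and the source may have more. Where it says the series, first, only, none or still open, it means among the compounds named here.

Compound 1, `CCC(=O)N(Cc1ccc(OC)c(O)c1)c1cc(OC)c(OC)c(OC)c1`, is the stronger of the two compounds measured here in a functional assay on KYSE-450 cells (Homo sapiens) for inhibition, read by MTT assay, with a stated time of 48 h (a lower number here means a stronger inhibitor, a higher number a weaker inhibitor), where compound 1 gives 98 nM. The other measured compound, compound 2, `C/C=C/C(=O)N(Cc1cc(OC)c(OC)c(OC)c1)c1ccc(OC)c(O)c1`, differs from compound 1 in more than one place, and in this assay compound 2 gives 9160 nM; the two values show a wide gap between them, well beyond the scatter, with compound 1 far in front.

Compound 3, `COc1ccc(CN(C(=O)CCCl)c2cc(OC)c(OC)c(OC)c2)cc1O`, has not yet been measured in this assay. It differs from compound 1 by a single change: chloro in place of hydrogen on a saturated chain carbon, two bonds along the chain from a carbonyl carbon. The rest of the molecule, including the shared core and the benzyl group, is kept as it stands in compound 1.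

Among the measured compounds shown here, since no measured pair isolates this change, the expectation for compound 3 rests on the value of compound 1 in this assay, 98 nM, and on the small size of the change. The step from compound 1 to compound 3 is expected to be modest, a 1.5-fold higher number from compound 1 to compound 3 (0.18 log units; within the scatter), and may well fall within the scatter. Compound 3 is therefore estimated to give 150 nM in this assay, with a plausible range from 40 nM to 600 nM.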

Compound 3, half-maximal inhibitory concentration: 110 nM
The estimate for compound 3 lay 1.4-fold (0.13 log units) above the measured number; the range from low to high includes it.
By their numbers in this assay, from the lowest: compounds 1 and 3 (each within the scatter of the next); then compound 2.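

In this assay, among the compounds shown here, the step from hydrogen to chloro on this saturated chain carbon, two bonds along the chain from a carbonyl carbon, is a 1.1-fold higher number from compound 1 to compound 3 (0.05 log units; within the scatter) and gives the first single-change reading at this position. The two numbers cannot be told apart, so this position on the propanoyl chain of compound 1 accepts a chloro group, and the 2-chloroethyl form keeps the strength that the ethyl form shows in this cell assay. The data offer no measured basis for explaining why this exchange leaves the two compounds so close.

This single exchange does not show how far that acceptance extends, since a larger halogen such as bromo, an amine or a carboxylic acid at the same carbon could behave quite differently from chloro. On these data alone, a longer chain in place of the propanoyl group, and any reading of the chloro compound beyond this assay, also remain open, so the result speaks for one group at one position in one assay.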